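The source may report more compounds than this note shows. Statements on the series, on what has been measured and on what is new or still open speak of the compounds shown alone.

For the measured compounds named here, compound 2 `O=C(Nc1ccc(Cl)cc1)Nc1nnc(Sc2ncnc3scc(-c4ccncc4)c23)s1` stands at 23300 nM in a functional assay on T47D cells (Homo sapiens) for antiproliferative activity, read by MTT assay, with a stated time of 48 h (on this read-out lower numbers stand for stronger inhibition and higher numbers for weaker inhibition), one of only two numbers; the other comes from compound 1 `O=C(Nc1ccc(F)cc1)Nc1nnc(Sc2ncnc3scc(-c4ccncc4)c23)s1`, which gives 18900 nM, and the step of a 1.2-fold higher number from compound 1 to compound 2 (0.09 log units; within the scatter) is within the scatter, so the two cannot be told apart. The next entry is compound 3 `COc1cccc(NC(=O)Nc2nnc(Sc3ncnc4scc(-c5ccncc5)c34)s2)c1`, which differs from compound 2 by 3-methoxyphenyl in place of 4-chlorophenyl on an amide-type nitrogen. Going by the values given here, no measured step covers this kind of change: the only step on record, a 1.2-fold higher number from compound 1 to compound 2 (0.09 log units; within the scatter), swaps one halogen for another on an aromatic carbon and stays within the scatter. Among the compounds with values here, it indicates only that the outer aryl ring has so far not moved this assay; the entering methoxyphenyl group, which brings a hydrogen-bond acceptor, has no precedent here. The step of a 1.2-fold lower number from compound 2 to compound 3 (0.07 log units; within the scatter) is expected to remain within the scatter, with a wide range given the lack of direct precedent. Compound 3 is estimated at 20000 nM, between 7000 nM and 60000 nM.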

Compound 3, half-maximal inhibitory concentration: 56900 nM
The estimate for compound 3 lay 2.8-fold (0.45 log units) below the measured number; the measured number falls inside the stated range.
By their numbers in this assay, from the lowest: compounds 1 and 2 (each within the scatter of the next); then compound 3.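

In this assay the group on the amide-type nitrogen does move the number: a 2.4-fold higher number from compound 2 to compound 3 (0.39 log units; beyond the scatter) and a 3.0-fold higher number from compound 1 to compound 3 (0.48 log units; beyond the scatter) are both beyond the scatter, though modest, whereas the exchange of one halogen for the other stayed within it. For the compounds shown here, both steps run towards weaker inhibition, so among the three compounds 3-methoxyphenyl is the one group that separates from the two halogenated phenyl groups. No available information bears on the origin of this step.

The entering group differs from 4-chlorophenyl in both its substituent and that substituent's place on the ring, so the compounds shown cannot assign the step to either. Also open, as far as these compounds go, is whether an amine, a carboxylic acid or a plain phenyl at this position would give a lower number than the halogenated compounds.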